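Working notes: the step from compound 3 to compound 4

This account rests on a few compounds, and the source may have more. Where it says the series, first, only, none or still open, it means among the compounds named here.

Measured in a functional assay on HL-60 cells (Homo sapiens) for cytotoxicity, read by WST assay, with a stated time of 48 h; a higher number here means that more compound is needed for the effect, a lower number that less compound is needed:
- compound 1 `O=C1OC[C@H](Cc2ccccc2)[C@H]1Cc1ccccc1`: 77000 nM
- compound 2 `CCCCOc1ccc(C[C@H]2C(=O)OC[C@@H]2Cc2ccccc2)cc1OCCCC`: > 100000 nM (a limit of the assay, not a number)
- compound 3 `Oc1ccccc1C[C@H]1COC[C@@H]1Cc1ccc(Cl)c(Cl)c1`: 34000 nM

Only two of the three results are numbers, since compound 2 stands at a limit: the limit of > 100000 nM in this assay, at which 1 of the 3 values shown sits. Of those two numbers, compound 3 at 34000 nM has the lower, so less of it is needed for the effect. The nearest is compound 1 at 77000 nM, and this gap lies beyond the usual scatter.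

Compound 4 `Fc1ccccc1C[C@H]1COC[C@@H]1Cc1ccc(Cl)c(Cl)c1` is the next structure to be measured. It carries fluoro in place of hydroxy on an aromatic carbon, ortho to a large group: fluoro in place of hydroxy on an aromatic carbon. For the measured compounds named here, no measured pair differs in one place only, so no direct precedent exists for the size of this change. In this assay no step beyond the scatter is expected, with at most a slight lean towards a higher number. Going by the values given here, the expectation rests on compound 3 at 34000 nM, the only measured compound that shares the core of compound 4.

The expected change, a 1.2-fold higher number from compound 3 to compound 4 (0.09 log units; within the scatter), is small. For compound 4 the estimated value is 42000 nM, with an expected range from 14000 nM to 95000 nM.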

Compound 4, half-maximal effective concentration: 51000 nM
Compound 4: middle estimate off by 1.2-fold (0.08 log units), on the low side; low and high end bracket the measured number.
By their numbers in this assay, from the lowest: compounds 3, 4 and 1 (each within the scatter of the next, the first and the last beyond it). At a limit, above all of these: compound 2.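

For the compounds shown here, the first step that differs in one place only, 2-hydroxyphenyl to 2-fluorophenyl in this assay, comes to a 1.5-fold higher number from compound 3 to compound 4 (0.18 log units; within the scatter), so this exchange on an aromatic carbon, ortho to a large group, is now measured directly. At this position, hydroxy with its one hydrogen-bond donor and one hydrogen-bond acceptor and fluoro with none of either cannot be told apart in this assay, as compound 3 gives 34000 nM and compound 4 gives 51000 nM, which lie within the scatter of each other. No measured property in the data bears on this step.

A single pair at one position leaves open whether other groups on the same aromatic carbon, such as plain hydrogen, methoxy, an amine or a carboxylic acid, would also stay within the scatter of compound 3 or would give a step beyond it. As far as these compounds go, it also remains open whether the same exchange of hydroxy for fluoro would give a similar step on the core of compound 1, or in any assay other than this assay.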